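Two Diacylhydrazines and a Bromophenyl Variant for Ecdysone Receptor Agonism

The source may report more compounds than this note shows. Statements on the series, on what has been measured and on what is new or still open speak of the compounds shown alone.

Measured compounds:
compound 1, `CC(C)(C)N(NC(=O)c1ccccc1)C(=O)c1ccc(Cl)cc1Cl`, 117 nM
compound 2, `CC(C)(C)N(NC(=O)c1ccccc1F)C(=O)c1ccccc1Cl`, 51.3 nM

Both compounds were tested in an assay on cells for agonist activity at ecdysone receptor (Bombyx mori), read by a luciferase reporter, with a stated time of 24 h; on this read-out higher numbers stand for an effect only at larger amounts of compound and lower numbers for an effect already at smaller amounts. Compound 1 gives 117 nM, and compound 2 gives 51.3 nM. Compound 2 therefore carries the lowest number of the two; its separation from compound 1 lies beyond the usual scatter. Among the measured compounds shown here, the two compounds differ in more than one place, so no single step between them can be read.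

Compound 3, `CC(C)(C)N(NC(=O)c1cccc(Br)c1)C(=O)c1ccccc1Cl`, has not yet been measured in this assay. It is reached from compound 2 by one change: 3-bromophenyl in place of 2-fluorophenyl on a carbonyl carbon. For the measured compounds named here, nothing measured so far shows what this exchange on the carbonyl carbon does; the only anchor is the value of compound 2.

With no guide from a comparable step, the expected result for compound 3 is a number close to that of compound 2, and the estimated step is a 1.6-fold higher number from compound 2 to compound 3 (0.19 log units; within the scatter), not clearly beyond the scatter in either direction. Compound 3 is thus expected to give about 80 nM, with a likely range from 25 nM to 250 nM.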

Compound 3, half-maximal effective concentration: 191 nM
Beside the measured number, compound 3's estimate is 2.4-fold (0.38 log units) below it; low and high end bracket the measured number.
By their numbers in this assay, from the lowest: compound 2; then compounds 1 and 3 (each within the scatter of the next).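

In this assay, among the compounds shown here, putting 3-bromophenyl in place of 2-fluorophenyl on a carbonyl carbon whose other neighbours are an amide-type nitrogen gives a 3.7-fold higher number from compound 2 to compound 3 (0.57 log units; beyond the scatter), the first step that can be read at this position, and it shows that the read-out responds to the exchange of this aromatic group. The groups that leave and enter have the same counts of heavy atoms, hydrogen-bond donors and acceptors, the same kind of six-membered aromatic ring and no net charge, so the step arises between groups that these counts do not distinguish, with the halogen and its printed ring position being what differs. Nothing available bears on why the number moves with this exchange.

On these data alone, whether the step follows the change of halogen or the change of its place on the ring stays open, as does what a methoxyphenyl or aminophenyl group would give on this carbonyl carbon. The steps from compound 1 to compound 2 and to compound 3 cannot be read, since each of these pairs differs in more than one place.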